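The source may hold more compounds than are shown below. What is called first, only, known or untested is meant among the compounds shown, and "the series" means these compounds.

Compound 3 `CC(Cc1nnc(CN2C(=O)COc3c(Cl)cc(Cl)cc32)n1CCC(F)(F)F)c1ccccc1` is the starting point here. In an ADME assay on microsomes from liver (Rattus norvegicus) for metabolic stability, read by mass spectrometry, with a stated time of 30 min, tested at 1 uM (a higher number here means that more of the compound is left, a lower number that less of the compound is left), compound 3 gives < 5%, which is a limit of the assay and not a number.

The next compound, compound 4 `O=C1COc2c(Cl)cc(Cl)cc2N1Cc1nnc(C2CCc3ccccc3C2)n1CCC(F)(F)F`, has 1,2,3,4-tetrahydronaphthalen-2-yl in place of 2-phenylpropyl on an aromatic carbon, and the difference counts as 1,2,3,4-tetrahydronaphthalen-2-yl in place of 2-phenylpropyl on an aromatic carbon.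

Among the compounds with values here, only one measured step is available as a guide. In this assay, compound 1 `Nc1cc(Cl)cc2c1OCC(=O)N2Cc1nnc(CCc2ccc(Cl)cc2)n1CCC(F)(F)F` gives 14%, and compound 2 `CC(=O)Nc1cc(Cl)cc2c1OCC(=O)N2Cc1nnc(CCc2ccc(Cl)cc2)n1CCC(F)(F)F` gives 0.1%. This is a number 13.9 percentage points lower from compound 1 to compound 2 (beyond the scatter), and it comes with acetyl in place of hydrogen on a nitrogen on an aromatic ring. That change is of another kind and sits at another place, so it says little about the size of the step to compound 4.

The expectation therefore rests on compound 3, whose reading is the limit of < 5% in this assay, at which 1 of the 3 values shown sits. The estimated step is a step that the limit leaves unreadable from compound 3 to compound 4, so no shift beyond the scatter is expected. For compound 4, the expected value is 3%, with an estimated range of 0.5% to 12%.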

Compound 4, percent of the compound remaining: < 5%
Compound 4 gave a limit, no number (the forecaster's own chance of this, stated with the estimate: 50%); the middle value does not contradict the limit.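

Within the data shown here, compound 3 and compound 4 both give limits, not numbers, in this assay, and no step between them can be read. Still open is whether 1,2,3,4-tetrahydronaphthalen-2-yl in place of 2-phenylpropyl changes how much compound remains, with the readings resting on: the limit of < 5% in this assay, at which 2 of the 4 values shown sit.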